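Chloro in Place of Methoxy: Expecting Compound 4

The source may report more compounds than this note shows. Statements on the series, on what has been measured and on what is new or still open speak of the compounds shown alone.

Of the compounds shown here, three have been measured in a functional assay on PC-12 cells (Rattus norvegicus) for cytotoxicity, read by MTT assay, with stated times of 3 h and 2 h, tested at 5 uM; a lower number here means a weaker effect, a higher number a stronger effect of the compound at the concentration tested. Compound 1 `O=C(CCCCC1CCSS1)NCc1cn(CCCOc2ccc3cc(-c4ccccc4)c(=O)oc3c2)nn1` gives 29.8%, compound 2 `O=C(CCCCC1CCSS1)NCc1cn(CCCCOc2ccc3ccc(=O)oc3c2)nn1` gives 52.8%, and compound 3 `COc1ccc(-c2cc3ccc(OCCCCn4cc(CNC(=O)CCCCC5CCSS5)nn4)cc3oc2=O)cc1` gives 44.9%, the second highest of the three numbers; compound 2 is its nearest neighbour, within the scatter, while compound 1 lies furthest from it, beyond the scatter. Going by the values given here, the only single-point step measured so far is a number 7.9 percentage points lower from compound 2 to compound 3 (within the scatter), which stays within the scatter.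

Compound 4 `O=C(CCCCC1CCSS1)NCc1cn(CCCCOc2ccc3cc(-c4ccc(Cl)cc4)c(=O)oc3c2)nn1` differs from compound 3 in one place: chloro in place of methoxy on an aromatic carbon. Among the compounds with values here, no measured step touches the group para to the large group, so the step between compound 2 and compound 3 is at best an indirect guide, and the gap between compound 1 and compound 3 involves more than one change. Within the data shown here, with no step of this kind measured, the step expected in this assay from compound 3 to compound 4 is a number 0.9 percentage points lower from compound 3 to compound 4 (within the scatter), within the scatter. Compound 4 is therefore estimated at 44%, with a range from 28% to 60%.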

Compound 4, a percentage reported as activity, at one concentration (the size of the read-out at that concentration, not a potency): 52%
Compound 4: the middle estimate sits 8 percentage points below what was measured; measured number inside the range.
By their numbers in this assay, from the lowest: compound 1; then compounds 3, 4 and 2 (each within the scatter of the next).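

Chloro in place of methoxy on this aromatic carbon, para to a large group, is the first change measured at this position, and in this assay it gives a number 7.1 percentage points higher from compound 3 to compound 4 (within the scatter), so the read-out does not separate these two groups here. The step of a number 0.8 percentage points lower from compound 2 to compound 4 (within the scatter) joins the earlier step of a number 7.9 percentage points lower from compound 2 to compound 3 (within the scatter), showing that neither 4-chlorophenyl nor 4-methoxyphenyl in place of hydrogen separates from compound 2 at this concentration. No available evidence bears on why these numbers fall as they do.

Going by these compounds, it remains open whether an amine or a carboxylic acid on the same aromatic carbon would give a step beyond the scatter. Also open, on these data alone, is how the gap to compound 1, which differs from these compounds in more than one place, divides among its changes.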